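The source may report more compounds than this note shows. Statements on the series, on what has been measured and on what is new or still open speak of the compounds shown alone.

The measured compounds in a functional assay on A-431 cells (Homo sapiens) for antiproliferative activity, read by sulforhodamine B assay, with a stated time of 72 h; a higher number here means a weaker inhibitor, a lower number a stronger inhibitor:
compound 1, `COCCNC(=O)Nc1cc2c(Nc3ccc(F)c(Cl)c3)ncnc2cc1O[C@H]1CCOC1`, giving 387 nM
compound 2, `CS(=O)(=O)CCNC(=O)Nc1cc2c(Nc3ccc(F)c(Cl)c3)ncnc2cc1O[C@H]1CCOC1`, giving 1570 nM
compound 3, `CN(C)CCN(C)C(=O)Nc1cc2c(Nc3ccc(F)c(Cl)c3)ncnc2cc1O[C@H]1CCOC1`, giving 450 nM

Compound 3 stands second highest of the three numbers. Its nearest neighbour is compound 1, with a 1.2-fold higher number from compound 1 to compound 3 (0.07 log units; within the scatter), a gap within the usual scatter. Its furthest is compound 2, with a 3.5-fold lower number from compound 2 to compound 3 (0.54 log units; beyond the scatter), a modest step beyond the scatter.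

Compound 4, `O=C(Nc1cc2c(Nc3ccc(F)c(Cl)c3)ncnc2cc1O[C@H]1CCOC1)N1CCC(F)(F)CC1`, has not yet been measured in this assay. It differs from compound 3 in one place: 4,4-difluoropiperidin-1-yl in place of (2-(dimethylamino)ethyl)(methyl)amino on a carbonyl carbon. Both measured steps into compound 3 exchanged the group on the same carbonyl carbon. Swapping one open-chain group for another there moved the number little, and the largest movement seen was a 4.1-fold higher number from compound 1 to compound 2 (0.61 log units; beyond the scatter), still modest. Within the data shown here, none of the measured groups on that carbonyl carbon contains a ring, so nothing tests a 4,4-difluoropiperidin-1-yl group directly. The step in this assay is therefore expected to be small, without a clear direction, and within or barely beyond the scatter. Compound 4 is expected to give 500 nM, in a range from 200 nM to 1300 nM, which is expected to correspond to a 1.1-fold higher number from compound 3 to compound 4 (0.05 log units; within the scatter).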

Compound 4, half-maximal inhibitory concentration: 1860 nM
Estimate against measurement, compound 4: 3.7-fold (0.57 log units) below; measured number outside the range, above it.
By their numbers in this assay, from the lowest: compounds 1 and 3 (each within the scatter of the next); then compounds 2 and 4 (each within the scatter of the next).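

In this assay, among these compounds, the 4,4-difluoropiperidin-1-yl group puts a ring on this carbonyl carbon for the first time, and the exchange gives a 4.1-fold higher number from compound 3 to compound 4 (0.62 log units; beyond the scatter) and a 4.8-fold higher number from compound 1 to compound 4 (0.68 log units; beyond the scatter), so compound 4 parts from the two open-chain compounds with the lower numbers. Against the third open-chain compound the same exchange gives a 1.2-fold higher number from compound 2 to compound 4 (0.07 log units; within the scatter), and compound 2, which has no ring, therefore goes against any reading that a ring alone separates groups at this position. Nothing measured here accounts for these steps.

The compounds shown leave open whether the ring or its two fluorine atoms goes with the higher number, which a piperidine ring without fluorine on the same carbonyl carbon would separate. They also leave open where a ring carrying an amine, such as a methylpiperazine, would fall.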